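The compounds below may be only part of what the source reports. "The series", "measured", "known", "first", "only" and "open" are said of these compounds alone.

Of the compounds shown here, three have been tested in an ADME assay on L929 cells (Mus musculus) for cytotoxicity, read by resazurin assay, with a stated time of 72 h (on this read-out lower numbers stand for stronger inhibition and higher numbers for weaker inhibition), and each gave only a limit of the measurement rather than a number. Compound 1 `OB1OCc2ccc(-n3cc(Sc4ccc(Cl)c(Cl)c4)c4ccccc43)cc21` gives > 10 ug/mL in this assay, which is such a limit. Compound 2 `CC(=O)c1ccn(-c2ccc3c(c2)B(O)OC3)c1` gives > 10 ug/mL in this assay, also a limit. Compound 3 `O=C(c1ccn(-c2ccc3c(c2)B(O)OC3)c1)c1ccc(Cl)cc1Cl` gives > 10 ug/mL in this assay, again a limit and not a number. Compound 3 therefore stands where all three values sit, at the limit of > 10 ug/mL in this assay, at which 3 of the 3 values shown sit. The step that the two limits leave unreadable from compound 2 to compound 3 cannot be read, since both of its ends are limits. Compound 4 `O=C(c1ccccc1)c1ccn(-c2ccc3c(c2)B(O)OC3)c1` differs from compound 3 by phenyl in place of 2,4-dichlorophenyl on a carbonyl carbon. Within the data shown here, the only measured step that touches this same carbonyl carbon is the one from compound 2 to compound 3, and its size is hidden by the limits, so no measured step gives a readable size for this kind of change. With nothing measurable to build on, no step beyond the scatter is expected in this assay in either direction. Compound 4 is therefore expected to give 20 ug/mL, within a range from 10 ug/mL to 60 ug/mL. The step that the limit leaves unreadable from compound 3 to compound 4 that this estimate implies is expected to stay within the scatter, and the result for compound 4 will most likely be reported as another limit rather than a number.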

Compound 4, half-maximal inhibitory concentration: > 10 ug/mL
Compound 4 gave a limit, no number (the forecaster's own chance of this, stated with the estimate: 85%); the middle value lies beyond the limit too.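

In this assay, compound 4 also gives only a limit, so the steps linking compound 2, compound 3 and compound 4 cannot be read, as each has a limit at both ends. The compounds shown leave open whether changing the group on the carbonyl carbon alters cytotoxicity at all, with every result at one shared limit: the limit of > 10 ug/mL in this assay, at which 4 of the 4 values shown sit.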